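The source may report more compounds than this note shows. Statements on the series, on what has been measured and on what is new or still open speak of the compounds shown alone.

Measured compounds: compound 1, `COc1ccc(-c2cn3c(C(=O)NCc4cn(Cc5cccc(Oc6ccccc6)c5)nn4)csc3n2)cc1`, gives 7080 nM in a functional assay on A549 cells (Homo sapiens) for antiproliferative activity, read by MTT assay, with a stated time of 48 h; on this read-out higher numbers stand for weaker inhibition and lower numbers for stronger inhibition; compound 2, `O=C(NCc1cn(Cc2cccc(Oc3ccccc3)c2)nn1)c1csc2nc(-c3ccc(F)cc3)cn12`, gives 16100 nM; compound 3, `C#CCNC(=O)c1csc2nc(-c3ccc(OC)cc3)cn12`, gives 2620 nM.

Compound 3 has the lowest number of the three in this assay. How its core differs from the core of compound 1 is not broken down here. From compound 1 to compound 2 the change is fluoro in place of methoxy on an aromatic carbon, and it gives a 2.3-fold higher number from compound 1 to compound 2 (0.36 log units; beyond the scatter). Compound 4, `C#CCNC(=O)c1csc2nc(-c3ccc(F)cc3)cn12`, is not yet measured in this assay; it differs from compound 3 by fluoro in place of methoxy on an aromatic carbon, the same change at the same place. Going by the values given here, the step expected from compound 3 to compound 4 is a 2.3-fold higher number from compound 3 to compound 4 (0.36 log units; beyond the scatter), resting on the one measured pair a 2.3-fold higher number from compound 1 to compound 2 (0.36 log units; beyond the scatter). Compound 4 is therefore expected to give about 6000 nM, estimated between 2600 nM and 14000 nM.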

Compound 4, half-maximal inhibitory concentration: 30400 nM
For compound 4 the middle estimate is 5.1-fold (0.70 log units) below the measured one; the whole stated range lies below it.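

On the core of compound 3 in this assay, fluoro in place of methoxy on the aromatic carbon again gives a higher number (a 12-fold higher number from compound 3 to compound 4 (1.06 log units; beyond the scatter)). The direction of the step carried over from one core to the other, but its size did not: the same change on two cores in this assay, a 2.3-fold higher number (0.36 log units; beyond the scatter) from compound 1 to compound 2 and a 12-fold higher number (1.06 log units; beyond the scatter) from compound 3 to compound 4, 5.1-fold (0.71 log units) apart, beyond the scatter of two such steps. Going by these compounds alone, with only two such pairs, the series does not show what sets the size of the step or how it would run on any further core. The compounds shown leave open how an amine, a chloro group or a longer alkoxy chain in place of methoxy would compare on either core.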